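Chain Extension on the Acrylamide of a Thienopyrimidine Series

The compounds below may be only part of what the source reports. "The series", "measured", "known", "first", "only" and "open" are said of these compounds alone.

Measured compounds:
compound 1, `COc1ccc(Nc2nc(Oc3cccc(NC(=O)/C=C/C(C)C)c3)c3sccc3n2)cc1`, 25200 nM
compound 2, `C/C=C/C(=O)Nc1cccc(Oc2nc(Nc3cccc(OC)c3)nc3ccsc23)c1`, 13100 nM
compound 3, `C/C=C/C(=O)Nc1cccc(Oc2nc(Nc3cccc(C#N)c3)nc3ccsc23)c1`, 20100 nM

The three compounds were tested in a functional assay on A-431 cells (Homo sapiens) for inhibition, read by MTT assay, with a stated time of 72 h; a lower number here means a stronger inhibitor, a higher number a weaker inhibitor. The number for compound 3 sits close to both others: compound 1 and compound 2 each lie within the usual scatter of it. Going by the values given here, the only single-place step among them, a 1.5-fold higher number from compound 2 to compound 3 (0.19 log units; within the scatter), concerns the substituent on the aniline ring and is itself within the scatter.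

Compound 4, `CCC/C=C/C(=O)Nc1cccc(Oc2nc(Nc3cccc(C#N)c3)nc3ccsc23)c1`, differs from compound 3 by ethyl in place of hydrogen on a saturated chain carbon bound to a double-bonded chain carbon, that is, on the unsaturated amide chain. Among the compounds with values here, no measured pair isolates this kind of chain extension: compound 1 and compound 2 carry different chains, but they also differ elsewhere, so only their two values can be compared, and those two lie within the scatter of each other. With nothing pointing to a change beyond the scatter, the step of a 1.0-fold lower number from compound 3 to compound 4 (0.00 log units; within the scatter) is expected to be small. Compound 4 is therefore estimated at 20000 nM in this assay, within a range of 7000 nM to 57000 nM.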

Compound 4, half-maximal inhibitory concentration: 20400 nM
Beside the measured number, compound 4's estimate is 1.0-fold (0.01 log units) below it; the range from low to high includes it.
By their numbers in this assay, from the lowest: compounds 2, 3, 4 and 1 (each within the scatter of the next).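

In this assay, going by these compounds alone, ethyl in place of hydrogen on a saturated chain carbon bound to a double-bonded chain carbon gives a 1.0-fold higher number from compound 3 to compound 4 (0.01 log units; within the scatter) and so provides the first reading of this chain with nothing else changed. Compound 1 and compound 2 carry different chains but also differ elsewhere, whereas this pair shows that, with the rest of compound 3 held fixed, prop-1-en-1-yl can become pent-1-en-1-yl without a change beyond the scatter. Nothing available bears on the reason for this result.

From the compounds shown here alone, what an amine or a longer chain at this saturated chain carbon would do remains open. Going by these compounds, it is also open whether ethyl would read the same way on compound 2, which carries methoxy in place of cyano.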